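A few compounds are considered here, and "the series" means these few. Any claim that something is new, unique, unknown or untested is made for them only; others in the source may bear on it.

Compound 1 `COc1cc(-c2cc(/C=C/C(=O)c3ccc(N)cc3)[nH]n2)cc(OC)c1OC` gives 4330 nM in a functional assay on Hs-578T cells (Homo sapiens) for inhibition, read by sulforhodamine B assay, with a stated time of 48 h; a higher number here means a weaker inhibitor of growth, a lower number a stronger inhibitor of growth. Compound 2 `COc1ccc(-c2cc(/C=C/C(=O)c3ccc(OC)c(OC)c3)[nH]n2)cc1` gives 3380 nM.

On these two numbers compound 1 and compound 2 lie within the scatter of each other, so neither can be set apart from the other. Compound 3 `COc1cc(-c2cc(/C=C/C(=O)c3ccc(F)c(F)c3)[nH]n2)cc(OC)c1OC` has not been measured. It differs from compound 1 in one place: 3,4-difluorophenyl in place of 4-aminophenyl on a carbonyl carbon. Among the measured compounds shown here, no measured pair shows the effect of this change, so the direction is open. Compound 3 is expected to stay close to compound 1, with the step of a 1.4-fold lower number from compound 1 to compound 3 (0.16 log units; within the scatter) expected to be no larger than the scatter. The estimate for compound 3 is 3000 nM, within a range of 800 nM to 12000 nM.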

Compound 3, concentration for 50% growth inhibition: 3580 nM
For compound 3 the middle estimate is 1.2-fold (0.08 log units) below the measured one; the measured number falls inside the stated range.
By their numbers in this assay, from the lowest: compounds 2, 3 and 1 (each within the scatter of the next).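

On the carbonyl carbon, 3,4-difluorophenyl in place of 4-aminophenyl gives a 1.2-fold lower number from compound 1 to compound 3 (0.08 log units; within the scatter) in this assay and so stays within the scatter. This first measured pair for the change shows that a group with 0 hydrogen-bond donors can take the place of one with 1 without a step beyond the scatter. No measurement at hand offers an explanation for this result.

On these data alone, whether a carboxylic acid or a morpholine on this carbonyl carbon would move the number beyond the scatter stays open. So does whether a plain phenyl would.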